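Oxindole benzylidenes against a melanoma cell line

The compounds below may be only part of what the source reports. "The series", "measured", "known", "first", "only" and "open" are said of these compounds alone.

Among the compounds with values here, the two compounds measured so far share a core carrying a 2,6-dichlorophenyl group on the ring nitrogen and differ in the arylidene arm. Compound 1 `O=C1/C(=C\c2cc3ccccc3nc2Cl)c2ccccc2N1c1c(Cl)cccc1Cl` has no result in a functional assay on B16-F10 cells (Homo sapiens) for cytotoxicity against B16-F10 (Mus musculus), read by MTT assay, with a stated time of 72 h (a lower number here means that less compound is needed, a higher number that more compound is needed for the effect), and stands as "not determined" (no result reported). For compound 2 `CN(C)c1ccc(/C=C2\C(=O)N(c3c(Cl)cccc3Cl)c3ccccc32)cc1` only a limit is known: in this assay compound 2 is reported as > 100 ug/mL, which is the limit of the assay the limit of > 100 ug/mL in this assay, at which 1 of the 2 values shown sits, rather than a number.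

Compound 3 `O=C1/C(=C\c2ccc(Cl)cc2)c2ccccc2N1c1c(Cl)cccc1Cl` is the next compound, not yet measured. It differs from compound 2 by chloro in place of dimethylamino on an aromatic carbon. Within the data shown here, with no measured step to lean on, the expected change from compound 2 to compound 3 is an at least 1.2-fold lower number from compound 2 to compound 3 (0.09 log units; that floor lies within the scatter), a shift that may well stay within the scatter. Compound 3 is therefore estimated at 80 ug/mL in this assay, with a range from 20 ug/mL to 250 ug/mL.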

Compound 3, concentration for half-maximal effect: > 100 ug/mL
Compound 3: only a limit was reported; the forecaster's own chance of this, stated with the estimate: 50%; at least 1.2-fold (0.09 log units) between middle value and limit.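

Compound 2 and compound 3 both stand at a limit rather than a number, so no step between them can be read: the limit of > 100 ug/mL in this assay, at which 2 of the 3 values shown sit.

The compounds shown leave open whether any arylidene arm on the shared core gives a measurable value in this assay.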